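A few compounds are considered here, and "the series" means these few. Any claim that something is new, unique, unknown or untested is made for them only; others in the source may bear on it.

Working notes on the series. Three compounds have numbers in a functional assay for inhibition, with Homo sapiens as the target; on this read-out lower numbers stand for stronger inhibition and higher numbers for weaker inhibition. Compound 1 `Cc1ccc(-c2ccnc(Nc3cccc(N(C)C)c3)n2)s1` gives 5700 nM. Compound 2 `Cc1cccc(Nc2nccc(-c3ccco3)n2)c1` gives 2100 nM. Compound 3 `Cc1cccc(Nc2nccc(-c3ccccn3)n2)c1` gives 700 nM, the lowest of the three numbers, with compound 2 nearest and compound 1 furthest, both beyond the scatter. Among the compounds with values here, the only single-point step among the measured compounds is a 3.0-fold lower number from compound 2 to compound 3 (0.48 log units; beyond the scatter), a modest gain on swapping a five-membered aromatic ring with one hetero atom for pyridin-2-yl.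

Compound 4 `Cc1cccc(Nc2nccc(-c3ccc(C)s3)n2)c1` is the next to be measured. It differs from compound 3 by 5-methylthiophen-2-yl in place of pyridin-2-yl on an aromatic carbon. The change undoes the type of swap seen between compound 2 and compound 3, so the step of a 3.0-fold lower number from compound 2 to compound 3 (0.48 log units; beyond the scatter) bears on it most directly and points toward a higher number, of a similar modest size. Within the data shown here, compound 1 also carries 5-methylthiophen-2-yl, but it differs from compound 3 at the other end of the core as well, so its value shows only that the one other compound with this group sits at the weak end of the series.

Compound 4 is therefore expected to come in at 2000 nM, with a range of 800 nM to 5000 nM. The expected step is a 2.9-fold higher number from compound 3 to compound 4 (0.46 log units; beyond the scatter), a modest loss.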

Compound 4, half-maximal inhibitory concentration: 1400 nM
For compound 4 the middle estimate is 1.4-fold (0.15 log units) above the measured one; the range from low to high includes it.
By their numbers in this assay, from the lowest: compounds 3, 4 and 2 (each within the scatter of the next, the first and the last beyond it); then compound 1.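

Within the data shown here, at this position of the shared core, on the aromatic carbon next to the ring nitrogen, this assay gives two steps for 5-methylthiophen-2-yl, (a 2.0-fold higher number from compound 3 to compound 4 (0.30 log units; within the scatter)) against pyridin-2-yl and (a 1.5-fold lower number from compound 2 to compound 4 (0.18 log units; within the scatter)) against furan-2-yl, so this group is not separated from either of the other two, and only the pair in (a 3.0-fold lower number from compound 2 to compound 3 (0.48 log units; beyond the scatter)) is resolved. With 5-methylthiophen-2-yl held constant, methyl in place of dimethylamino gives (a 4.1-fold lower number from compound 1 to compound 4 (0.61 log units; beyond the scatter)), so the high number of compound 1 goes with the dimethylamino change and not with 5-methylthiophen-2-yl. No supporting measurement accounts for either result.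

On these data alone, it remains open whether the methyl on the thiophene matters, which an unsubstituted thiophen-2-yl would address, and whether a group of another kind at this position, such as a carboxylic acid or a saturated amine, would move the number further than these aromatic rings do. Also open, as far as these compounds go, is whether the step between methyl and dimethylamino keeps its size when pyridin-2-yl occupies this position.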